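A methyl group added to compound 2

The compounds below may be only part of what the source reports. "The series", "measured", "known", "first", "only" and "open" are said of these compounds alone.

Values in a physicochemical assay for solubility, measured as kinetic solubility, with a stated time of 1 h, at pH 7.4 (on this read-out lower numbers stand for lower solubility and higher numbers for higher solubility), are these
compound 1 `NC1=NN(c2ccc(Cl)c(Cl)c2)CC1` gives 69000 nM
compound 2 `CC(=O)NC1=NN(c2ccc(Cl)c(Cl)c2)CC1` gives 31000 nM
compound 3 `N#CCCC(=O)NC1=NN(c2ccc(Cl)c(Cl)c2)CC1` gives 39000 nM

Compound 2 is placed by a 1.3-fold higher number from compound 2 to compound 3 (0.10 log units; within the scatter) and by a 2.2-fold lower number from compound 1 to compound 2 (0.35 log units; beyond the scatter) on these numbers. Compound 4 `CC(=O)NC1=NN(c2ccc(Cl)c(Cl)c2)C[C@@H]1C` has methyl in place of hydrogen on a saturated ring carbon. Among the measured compounds shown here, no measured step touches that ring carbon. The steps at hand lie elsewhere in the molecule, and they are small, such as a 1.8-fold lower number from compound 1 to compound 3 (0.25 log units; within the scatter) in this set. So in this assay the expected step is small, a slight fall that likely stays within the scatter (a 1.2-fold lower number from compound 2 to compound 4 (0.08 log units; within the scatter)). Compound 4 is estimated at 26000 nM with a likely range from 11000 nM to 55000 nM in this read-out.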

Compound 4, solubility: 32000 nM
The estimate for compound 4 lay 1.2-fold (0.09 log units) below the measured number, within the range that was stated.
By their numbers in this assay, from the lowest: compounds 2, 4, 3 and 1 (each within the scatter of the next, the first and the last beyond it).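

In this assay, the saturated ring carbon next to the ring atom that bears an acetamido group now has a step of its own, and putting methyl in place of hydrogen there gives a 1.0-fold higher number from compound 2 to compound 4 (0.01 log units; within the scatter). Among the compounds shown here, the earlier steps all lay on the amine nitrogen or its chain, so this is the first reading from the ring itself, and the two numbers cannot be told apart. No evidence here explains this result.

A single small group says little about this ring carbon as a whole. As far as these compounds go, a longer chain, a hydroxyl group or an amine at the same place could read differently, and the other spatial arrangement of the methyl remains open too.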